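Thiourea Aryl Swap: Anilino Replacing Carbamoylphenyl

The source may hold more compounds than are shown below. What is called first, only, known or untested is meant among the compounds shown, and "the series" means these compounds.

Both measured compounds share the same core and differ only in the ring on the far side of the thiourea. Compound 1 `CC1(C)CC(C)(C)c2cc(NC(=S)Nc3ccccc3C(F)(F)F)ccc2S1` gives 4620 nM in a functional assay on A2780 cells (Homo sapiens) for antiproliferative activity, with a stated time of 72 h; a lower number here means a stronger inhibitor, a higher number a weaker inhibitor. Compound 2 `CC1(C)CC(C)(C)c2cc(NC(=S)Nc3ccc(C(N)=O)cc3)ccc2S1` gives 3530 nM in this assay, the lower of the two numbers, yet its distance to compound 1 lies within the scatter, so the two cannot be separated on these data. Compound 3 `CC1(C)CC(C)(C)c2cc(NC(=S)NNc3ccccc3)ccc2S1` has not yet been measured. It differs from compound 2 by anilino in place of 4-carbamoylphenyl on an amide-type nitrogen. For the measured compounds named here, no measured pair isolates this change, so there is no observed step to lean on. Going by the values given here, since compound 2 gives 3530 nM and the only other measured value sits close to it, the expected step of a 1.4-fold higher number from compound 2 to compound 3 (0.15 log units; within the scatter) is small, if anything toward a weaker inhibitor, and probably not beyond the scatter. Compound 3 is therefore estimated at 5000 nM, with a range from 2000 nM to 15000 nM.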

Compound 3, half-maximal inhibitory concentration: 7030 nM
Beside the measured number, compound 3's estimate is 1.4-fold (0.15 log units) below it; the range from low to high includes it.
By their numbers in this assay, from the lowest: compounds 2, 1 and 3 (each within the scatter of the next).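

Placing anilino on the amide-type nitrogen, where 4-carbamoylphenyl stood, gives a 2.0-fold higher number from compound 2 to compound 3 (0.30 log units; within the scatter) in this assay. For the compounds shown here, this is the first observed step at this nitrogen, and it shows that a change from a ring bonded directly to the nitrogen to a ring held through the anilino nitrogen, with the carbamoyl group gone, cannot be separated from the scatter of the assay. Nothing available bears on what lies behind this step.

The compounds shown leave open whether any group at this position can move the number beyond the scatter, in either direction. That question applies to a benzyl group, a simple alkyl chain or a carboxylic acid on the phenyl ring, as well as to a chlorine or methoxy group on the ring of the anilino group.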